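Aryl swap on the ring amine nitrogen of compound 3

The source may hold more compounds than are shown below. What is called first, only, known or untested is meant among the compounds shown, and "the series" means these compounds.

Three compounds have numbers in a functional assay on the whole organism (Abdomen, strain Swiss) for inhibition, with Mus musculus as the target, with stated times of 30 min, 10 min and 5 min, at a dose of 40 mg/kg by the oral route; on this read-out lower numbers stand for a weaker effect and higher numbers for a stronger effect at the one dose given. Within the data shown here, compound 1 `C=Cc1c(CC)nn(CCCN2CCN(c3ccc(C)cc3)CC2)c(=O)c1N` gives 28%, and compound 2 `C=Cc1c(CCC)nn(CCCN2CCN(c3ccc(C)cc3)CC2)c(=O)c1N` gives 22%; the only single-point step among the measured set, a number 6 percentage points lower from compound 1 to compound 2 (within the scatter), concerns the chain on the core of compound 1 and tells nothing about the aryl group. Compound 3 `CC(=O)c1cccn1CCCN1CCN(c2cccc(Cl)c2)CC1` gives 54%, the highest of the three numbers, beyond the scatter from both compound 1 and compound 2.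

Compound 4 `CC(=O)c1cccn1CCCN1CCN(c2ccc(C)cc2)CC1` is compound 3 with a changed aryl group: 4-methylphenyl in place of 3-chlorophenyl on an amine nitrogen in a ring. Among the measured compounds shown here, no measured step bears on this change; compound 1 and compound 2 carry the 4-methylphenyl group, but on a different core, so their values show only that this group is compatible with a modest read-out in this assay, not what the swap does on the core of compound 3. For the measured compounds named here, with no directly relevant step, the expectation rests on compound 3 alone, widened for the uncertainty of an untested change and for the fact that the measured 4-methylphenyl compounds sit lower.

Compound 4 is therefore estimated at 42%, within 18% to 64%, which means an expected step of a number 12 percentage points lower from compound 3 to compound 4 (beyond the scatter), a change not clearly beyond the scatter.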

Compound 4, a percentage reported as inhibition, in the whole organism at one dose (the size of the read-out at that dose, not a potency): 9%
Estimate against measurement, compound 4: 33 percentage points above; the whole stated range lies above it.
By their numbers in this assay, from the lowest: compound 4; then compounds 2 and 1 (each within the scatter of the next); then compound 3.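

Among these compounds, on the shared core, the aryl group on the amine nitrogen in a ring turns out to be a position that the read-out follows closely: in this assay the swap to 4-methylphenyl gives a number 45 percentage points lower from compound 3 to compound 4 (beyond the scatter) and is the first step to go beyond the scatter. The step arises between two groups equal in heavy-atom count, each with one six-membered aromatic ring of carbon only and neither with hydrogen-bond donors or acceptors, so those counts alone do not predict the outcome at this position. No supporting measurement bears on why the step is this large.

As far as these compounds go, the swap changes both the substituent and its place on the phenyl ring, so it remains open whether the loss follows the exchange of chlorine for methyl or the move from the 3-position to the 4-position; 4-chlorophenyl and 3-methylphenyl on the same nitrogen would separate the two. From the compounds shown here alone, it also remains open whether 3-chlorophenyl would have a comparable effect on the core of compound 1, where only 4-methylphenyl appears.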